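Two Fluorines on One Ring: Estimating Compound 3

A few compounds are considered here, and "the series" means these few. Any claim that something is new, unique, unknown or untested is made for them only; others in the source may bear on it.

Measured so far:
compound 1, `Oc1nc2nonc2nc1Nc1ccccc1F`, 12500 nM
compound 2, `Oc1nc2nonc2nc1Nc1cccc(C(F)(F)F)c1`, 13300 nM

Of the compounds shown here, two sharing one core have been tested in an assay on mitochondria from L6 cells (Rattus norvegicus) for activation, with a stated time of 90 min; a higher number here means that more compound is needed for the effect, a lower number that less compound is needed. Compound 1, `Oc1nc2nonc2nc1Nc1ccccc1F`, gives 12500 nM. Compound 2, `Oc1nc2nonc2nc1Nc1cccc(C(F)(F)F)c1`, gives 13300 nM. Compound 2 holds the highest of the two numbers, yet its nearest neighbour, compound 1, lies within the scatter of it, so the two cannot be told apart on these data. Within the data shown here, no pair among the measured compounds differs in a single place, so no measured step exists to guide the next one.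

Compound 3, `Oc1nc2nonc2nc1Nc1cc(C(F)(F)F)ccc1F`, is the next to be measured in this assay. It differs from compound 2 by fluoro in place of hydrogen on an aromatic carbon. This brings together in one molecule the fluoro of compound 1 and the trifluoromethyl of compound 2. With both parents giving numbers within the scatter of each other, no step beyond the scatter is expected; the estimated step of a 1.3-fold lower number from compound 2 to compound 3 (0.12 log units; within the scatter) is small and directed slightly downward. For compound 3 the estimated value is 10000 nM, expected to fall between 4000 nM and 25000 nM.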

Compound 3, half-maximal effective concentration: 5100 nM
Beside the measured number, compound 3's estimate is 2.0-fold (0.29 log units) above it; low and high end bracket the measured number.
By their numbers in this assay, from the lowest: compound 3; then compounds 1 and 2 (each within the scatter of the next).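

In this assay, among these compounds, fluoro in place of hydrogen on an aromatic carbon, ortho to a large group and para to a trifluoromethyl group, brings a 2.6-fold lower number from compound 2 to compound 3 (0.42 log units; beyond the scatter), the first step in this small set that lies beyond the scatter. Seen from the other parent, the added trifluoromethyl group brings a 2.5-fold lower number from compound 1 to compound 3 (0.39 log units; beyond the scatter), so that in these two comparisons, each group, added to a compound that already carries the other, goes with a modest fall in the number. Nothing available on these compounds bears on the cause of either step.

The compounds shown leave open whether this position favours fluoro in particular or would accept chlorine, a methyl group, a methoxy group or an amine in its place. Among the compounds shown here, they also leave open how large the fluoro step would be without the trifluoromethyl group, since no compound with hydrogen at both places appears among them, and whether a carboxylic acid or a longer chain on the same ring would carry the number lower still.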